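Swapping a Trifluoromethyl for a Nitro Group

A few compounds are considered here, and "the series" means these few. Any claim that something is new, unique, unknown or untested is made for them only; others in the source may bear on it.

Three measured compounds share one core and differ only in the group on the aromatic ring that bears the amide nitrogen. Compound 1 `O=C(Nc1ccccc1F)c1ccc2cccc(O)c2n1` carries a fluoro group and gives 2.5 in a physicochemical assay for lipophilicity, read by HPLC; a lower number here means a more polar compound, a higher number a more lipophilic compound. Compound 2 `O=C(Nc1ccccc1Br)c1ccc2cccc(O)c2n1` carries a bromo group and gives 2.5 in this assay. Compound 3 `O=C(Nc1ccccc1C(F)(F)F)c1ccc2cccc(O)c2n1` carries a trifluoromethyl group and gives 2.5 in this assay, so compound 3 sits level with the other two at the digits shown.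

The unmeasured compound 4 `O=C(Nc1ccccc1[N+](=O)[O-])c1ccc2cccc(O)c2n1` differs from compound 3 in one place: nitro in place of trifluoromethyl on an aromatic carbon. Going by the values given here, the steps that bear on this change are the two that end in the trifluoromethyl of compound 3: no change at the digits printed from compound 1 to compound 3 (within the scatter) and no change at the digits printed from compound 2 to compound 3 (within the scatter), neither of which moved this assay beyond the scatter. Those steps exchanged halogens for a trifluoromethyl, and none of them brought in hydrogen-bond acceptors; the change to compound 4 does bring in two. A small step downward is therefore expected, close to the scatter, described by a number 0.30 log units lower from compound 3 to compound 4 (within the scatter). For compound 4 the expected value in this assay is 2.2, with a range from 1.7 to 2.7.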

Compound 4, partition coefficient: 2.5
Beside the measured number, compound 4's estimate is 0.30 log units below it; low and high end bracket the measured number.
By their numbers in this assay, from the lowest: compounds 1, 2, 3 and 4 (each within the scatter of the next).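

The earlier compounds shown here exchanged only fluoro, bromo and trifluoromethyl, and none of those steps brought in a hydrogen-bond acceptor, so they could not show whether acceptors at this position, on an aromatic carbon ortho to a large group, would register in this assay at all. The nitro group does bring them in, and the reading shows no change at the digits printed from compound 3 to compound 4 (within the scatter) and no change at the digits printed from compound 2 to compound 4 (within the scatter) and also no change at the digits printed from compound 1 to compound 4 (within the scatter) in the same measurement. All four groups now sit level at this one place, whether or not they carry hydrogen-bond acceptors, and no measured information accompanies these numbers to explain that.

On these data alone, whether the level reading would hold for a group of another kind at this place, such as an amine, a carboxylic acid or a longer chain, stays open in this assay as well. The compounds shown also say nothing about the same exchange of trifluoromethyl for nitro at another place on this ring, or about a compound with only hydrogen at this position.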